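The source may hold more compounds than are shown below. What is called first, only, known or untested is meant among the compounds shown, and "the series" means these compounds.

Measured so far in an in vivo ADME assay on the whole organism (plasma) for pharmacokinetics, with Rattus norvegicus as the target, at a dose of 50 mg/kg by the oral route; a lower number here means less compound in the circulation, a higher number more compound in the circulation at the dose given:
- compound 1 `Cc1cc(C)c(NC(=O)c2sccc2S(=O)(=O)Nc2onc(C)c2Cl)c(C)c1CO` gives 5110 nM
- compound 2 `Cc1cc(C)c(S(N)(=O)=O)c(C)c1NC(=O)c1sccc1S(=O)(=O)Nc1onc(C)c1Cl` gives 5590 nM

With only these two numbers available, compound 2 has a single neighbour, and the comparison with compound 1 shows a 1.1-fold higher number from compound 1 to compound 2 (0.04 log units; within the scatter) in this assay between them. The two therefore cannot be ranked. The next structure is compound 3 `Cc1cc(C)c(NC(=O)c2sccc2S(=O)(=O)Nc2onc(C)c2Cl)c(C)c1C#N`, which keeps the core of compound 2 and carries one change, cyano in place of sulfamoyl on an aromatic carbon is the full count of that swap. For the measured compounds named here, only one measured step bears on it, the replacement of hydroxymethyl by sulfamoyl on that same aromatic carbon, and that step, a 1.1-fold higher number from compound 1 to compound 2 (0.04 log units; within the scatter) as measured, stayed small. Going by the values given here, no measured compound carries a cyano group, so this single step is thin evidence. On that basis, no step beyond the scatter is expected, and no direction is favoured. The expected result is a 1.1-fold lower number from compound 2 to compound 3 (0.05 log units; within the scatter) in this assay for this swap. For compound 3 the estimate is 5000 nM as the middle value, with an expected range from 2200 nM to 11000 nM at this dose.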

Compound 3, maximal plasma concentration: 37200 nM
The estimate for compound 3 lay 7.4-fold (0.87 log units) below the measured number, outside the stated range (above it).
By their numbers in this assay, from the lowest: compounds 1 and 2 (each within the scatter of the next); then compound 3.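

In this assay, the aromatic carbon that looked indifferent when hydroxymethyl and sulfamoyl were exchanged turns out to be able to shift the maximal plasma concentration, as cyano in place of sulfamoyl gives a 6.7-fold higher number from compound 2 to compound 3 (0.82 log units; beyond the scatter) at this position. Cyano in place of hydroxymethyl gives a step of similar printed size, a 7.3-fold higher number from compound 1 to compound 3 (0.86 log units; beyond the scatter) on the same carbon, so cyano stands apart from both earlier groups, while those two remain within the scatter of each other. Nothing measured here accounts for this separation, and the data give no reason why cyano differs from the other two groups.

As far as these compounds go, whether the higher number is particular to cyano or would also appear with another group on this carbon, such as a chlorine, an amine or a carboxylic acid, remains open. Also open is whether the step would hold on a different core or carry over to other pharmacokinetic read-outs, since the three compounds share one core and only the maximal plasma concentration is shown.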